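Swapping 4-methoxyphenyl for 2,4-dichlorophenyl on a shared core

A few compounds are considered here, and "the series" means these few. Any claim that something is new, unique, unknown or untested is made for them only; others in the source may bear on it.

Measured in a functional assay on HT-1080 cells (Homo sapiens) for cytotoxicity, read by MTT assay, with a stated time of 72 h; a higher number here means a weaker inhibitor, a lower number a stronger inhibitor:
- compound 1 `COc1ccccc1/C=C1\CCC/C(=C\c2ccc(OC)c(OC)c2)C1=O`: 8100 nM
- compound 2 `COc1cccc(/C=C2\CCC/C(=C\c3ccc(OC)c(OC)c3)C2=O)c1`: 4600 nM
- compound 3 `COc1ccc(/C=C2\CCC/C(=C\c3ccc(OC)c(OC)c3)C2=O)cc1`: 7200 nM

These three compounds differ only in where a methoxy group sits on one ring. Compound 3 cannot be separated from the other two: the data show a 1.1-fold lower number from compound 1 to compound 3 (0.05 log units; within the scatter) and a 1.6-fold higher number from compound 2 to compound 3 (0.19 log units; within the scatter). The remaining pair gives a 1.8-fold lower number from compound 1 to compound 2 (0.25 log units; within the scatter). All three steps are small, so moving the methoxy group has shown no clear effect on these numbers.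

Compound 4 `COc1ccc(/C=C2\CCC/C(=C\c3ccc(Cl)cc3Cl)C2=O)cc1OC` makes a different kind of change: 2,4-dichlorophenyl in place of 4-methoxyphenyl on a double-bonded chain carbon bound to a double-bonded ring carbon. Within the data shown here, no measured compound carries chlorine, so the steps above bear on this swap only indirectly and leave its direction open. With a 1.6-fold higher number from compound 2 to compound 3 (0.19 log units; within the scatter) as the nearest guide, no step beyond the scatter is expected, though the uncertainty is wide. The expected change is a 1.4-fold lower number from compound 3 to compound 4 (0.16 log units; within the scatter). For compound 4 the estimated value is 5000 nM, with an expected range from 1800 nM to 12000 nM.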

Compound 4, half-maximal inhibitory concentration: 10500 nM
Estimate against measurement, compound 4: 2.1-fold (0.32 log units) below; the range from low to high includes it.
By their numbers in this assay, from the lowest: compounds 2, 3, 1 and 4 (each within the scatter of the next, the first and the last beyond it).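

In this assay, placing 2,4-dichlorophenyl on this double-bonded chain carbon gives a 1.5-fold higher number from compound 3 to compound 4 (0.16 log units; within the scatter) and a 1.3-fold higher number from compound 1 to compound 4 (0.11 log units; within the scatter), so this ring cannot be told apart from either of those two methoxyphenyl rings. Only a 2.3-fold higher number from compound 2 to compound 4 (0.36 log units; beyond the scatter) passes beyond the scatter, and the step is modest, so this position has now taken a ring with chlorine in place of one with methoxy without any large shift in the numbers. No supporting measurement is available to explain that single larger step.

On these data alone, whether an amine or a carboxylic acid on this ring would move the number further remains open. So does whether any group at this position can bring the number well below those of the four compounds shown.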